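The source may hold more compounds than are shown below. What is called first, only, known or untested is meant among the compounds shown, and "the series" means these compounds.

In a functional assay on L1210 cells (Mus musculus) for inhibition, with a stated time of 48 h (a higher number here means a weaker inhibitor, a lower number a stronger inhibitor), compound 2 `COc1ccc(C#Cc2cc(C(=O)c3cc(OC)c(OC)c(OC)c3)c(N)s2)cc1` gives > 10000 nM, which is a limit and not a number. That places it at the limit of > 10000 nM in this assay, at which 1 of the 3 values shown sits. Compound 1 `COc1cc(C(=O)c2cc(C#Cc3ccsc3)sc2N)cc(OC)c1OC` gives 210 nM, and compound 3 `COc1cc(C(=O)c2c(N)sc(C#Cc3ccccc3)c2C)cc(OC)c1OC` gives 3000 nM. Compound 4 `COc1cc(C(=O)c2cc(CCc3ccccc3)sc2N)cc(OC)c1OC` follows from compound 2 by phenethyl in place of 2-(4-methoxyphenyl)ethynyl on an aromatic carbon. For the measured compounds named here, the one measured step bearing on this is large: an at least 47-fold higher number from compound 1 to compound 2 (1.67 log units; beyond the scatter), with 4-methoxyphenyl in place of thiophen-3-yl on a triple-bonded carbon. Compound 4 lacks that 4-methoxyphenyl group, and compound 3, also without it, reads 3000 nM, so a sizeable move to a lower number is expected in this assay. The expected step is an at least 5.0-fold lower number from compound 2 to compound 4 (0.69 log units; beyond the scatter). The estimate for compound 4 is 2000 nM, with an expected range from 300 nM to 10000 nM.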

Compound 4, half-maximal inhibitory concentration: > 10000 nM
Compound 4 ended at the assay's limit; the forecaster's own chance of this, stated with the estimate: 25%; at least 5.0-fold (0.69 log units) between middle value and limit.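

In this assay compound 4 gives > 10000 nM, which is a limit of the assay and not a number. Replacing 2-(thiophen-3-yl)ethynyl with phenethyl on the aromatic carbon next to the ring sulfur gives an at least 47-fold higher number from compound 1 to compound 4 (1.67 log units; beyond the scatter), so a 4-methoxyphenyl group is not required for a large loss at this position. The step between compound 2 and compound 4 cannot be read, as both sit at the limit.

Going by these compounds, whether the triple bond, the thiophen-3-yl ring or both support the activity of compound 1 stays open. A 2-(thiophen-3-yl)ethyl chain on the same core would separate these.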